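The source may hold more compounds than are shown below. What is called first, only, known or untested is meant among the compounds shown, and "the series" means these compounds.

Measured compounds:
Compound 1 `COc1cccc(CN2Cc3c(NC(=O)c4ccccc4)n[nH]c3C2(C)C)c1` gives 1120 nM in an assay on Sf21 cells for inhibition of high affinity nerve growth factor receptor (Homo sapiens), read by HTRF, with a stated time of 30 min, in the presence of a further agent that is not named here; a lower number here means a stronger inhibitor, a higher number a weaker inhibitor.
Compound 2 `CC1(C)c2[nH]nc(NC(=O)c3ccccc3)c2CN1Cc1ccccc1F` gives 450 nM in this assay.
Compound 3 `CC1(C)c2[nH]nc(NC(=O)c3ccccc3)c2CN1Cc1ccc(F)cc1F` gives 2320 nM in this assay.

Compound 1 stands second highest of the three numbers, with compound 3 nearest and compound 2 furthest. Compound 4 `Cc1ccc(F)c(CN2Cc3c(NC(=O)c4ccccc4)n[nH]c3C2(C)C)c1` differs from compound 1 by 2-fluoro-5-methylphenyl in place of 3-methoxyphenyl on a saturated chain carbon bound to an amine nitrogen in a ring. Among the measured compounds shown here, two measured steps bear on this. For the measured compounds named here, the step of a 2.5-fold lower number from compound 1 to compound 2 (0.40 log units; beyond the scatter) shows the 2-fluorophenyl alone lowering the number, while a 5.2-fold higher number from compound 2 to compound 3 (0.71 log units; beyond the scatter) shows a further fluoro raising it; the methyl in compound 4 has no measured precedent. A modest lowering from compound 1 is therefore expected for compound 4, roughly a 1.6-fold lower number from compound 1 to compound 4 (0.20 log units; within the scatter). Compound 4 is estimated at 700 nM, with a range of 300 nM to 1600 nM in this assay.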

Compound 4, half-maximal inhibitory concentration: 880 nM
The estimate for compound 4 lay 1.3-fold (0.10 log units) below the measured number; measured number inside the range.
By their numbers in this assay, from the lowest: compounds 2, 4 and 1 (each within the scatter of the next, the first and the last beyond it); then compound 3.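

On the saturated chain carbon bound to an amine nitrogen in a ring, 2-fluoro-5-methylphenyl cannot be told apart from 3-methoxyphenyl in this assay, with a 1.3-fold lower number from compound 1 to compound 4 (0.10 log units; within the scatter). Adding methyl to the 2-fluorophenyl of compound 2 also gives no resolved change, with a 2.0-fold higher number from compound 2 to compound 4 (0.29 log units; within the scatter), whereas a 2.6-fold lower number from compound 3 to compound 4 (0.42 log units; beyond the scatter) shows that a second substituent need not match the fluoro of compound 3. No evidence here explains these differences.

On these data alone, what a pyridine in place of the phenyl, or an amine or a carboxylic acid on it, would do remains open.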